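Methyl in Place of Nitro: Expected Effect on Compound 4

The source may report more compounds than this note shows. Statements on the series, on what has been measured and on what is new or still open speak of the compounds shown alone.

Compound 1 `CSc1ccc(-c2nc3c(=O)n(C)c(=O)n(C)c3[nH]2)cc1`: 2 nM
Compound 2 `Cn1c(=O)c2nc(-c3cccc(F)c3)[nH]c2n(C)c1=O`: 4 nM
Compound 3 `Cn1c(=O)c2nc(-c3cccc([N+](=O)[O-])c3)[nH]c2n(C)c1=O`: 50 nM

Of the compounds shown here, three sharing one core have been measured in an assay for binding affinity to adenosine receptor A1 (Bos taurus); on this read-out lower numbers stand for stronger inhibition and higher numbers for weaker inhibition. Compound 3 carries the highest number of the three: in this assay compound 3 gives 50 nM, whereas compound 2 gives 4 nM and compound 1 gives 2 nM. Among the compounds with values here, the single step that bears on the present question is the one between compound 2 and compound 3, a 13-fold higher number from compound 2 to compound 3 (1.10 log units; beyond the scatter).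

Compound 4 `Cc1cccc(-c2nc3c(=O)n(C)c(=O)n(C)c3[nH]2)c1` is the next compound in line. It differs from compound 3 in one place: methyl in place of nitro on an aromatic carbon. Within the data shown here, no measured pair shows methyl directly against nitro, so the nearest guide is the step from fluoro to nitro, which raised the number well beyond the scatter. Removing the nitro again in favour of another small group is therefore expected to bring the number back down, in the direction of compound 2, with an estimated step of a 10-fold lower number from compound 3 to compound 4 (1.00 log units; beyond the scatter).

On that basis compound 4 is expected to give about 5 nM in this assay, with a range from 2 nM to 15 nM.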

Compound 4, half-maximal inhibitory concentration: 13 nM
Beside the measured number, compound 4's estimate is 2.6-fold (0.41 log units) below it; the range from low to high includes it.
By their numbers in this assay, from the lowest: compounds 1 and 2 (each within the scatter of the next); then compound 4; then compound 3.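

In this assay the exchange of nitro for methyl gives a 3.8-fold lower number from compound 3 to compound 4 (0.59 log units; beyond the scatter) and so shows that the high number of compound 3 is not shared by every group other than fluoro at this position. The recovery is only partial, however, for the methyl compound still lies on the weaker side of the fluoro compound, with a 3.3-fold higher number from compound 2 to compound 4 (0.51 log units; beyond the scatter) separating them, and all three groups at this aromatic carbon now stand apart beyond the scatter, with fluoro giving the lowest number, methyl an intermediate one and nitro the highest. This position therefore distinguishes even between two groups as small as fluoro and methyl, but no measurement offered here accounts for the order of the three groups.

With only three groups compared at this position, the compounds shown leave open where others such as an amine, a hydroxyl group, a carboxylic acid or a longer chain like ethyl would fall in this order. They also leave open whether the same order of fluoro, methyl and nitro would hold at any other carbon of the ring or on a different core.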